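Chalcone-type series on hepatoma cells: indolyl to dimethoxyphenyl

A few compounds are considered here, and "the series" means these few. Any claim that something is new, unique, unknown or untested is made for them only; others in the source may bear on it.

Measured so far:
compound 1 `COc1ccc(OC)c(C(=O)/C=C/c2cn(-c3ccccc3)nc2-c2ccsc2)c1` 2100 nM
compound 2 `O=C(/C=C/c1cn(-c2ccccc2)nc1-c1cccnc1)c1c[nH]c2ccccc12` 3200 nM

In a functional assay on Huh-7 cells (Homo sapiens) for inhibition, read by sulforhodamine B assay, with a stated time of 72 h (on this read-out lower numbers stand for stronger inhibition and higher numbers for weaker inhibition), compound 2 gives 3200 nM, and compound 1 gives 2100 nM in this assay; the two numbers lie within the scatter of each other, so neither can be called the stronger. Compound 3 `COc1ccc(C(=O)/C=C/c2cn(-c3ccccc3)nc2-c2cccnc2)c(OC)c1` is not yet measured; it differs from compound 2 by 2,4-dimethoxyphenyl in place of 1H-indol-3-yl on a carbonyl carbon. Going by the values given here, no step between measured compounds is on record for this change, so the expected step of a 1.2-fold lower number from compound 2 to compound 3 (0.09 log units; within the scatter) is none beyond the scatter, in either direction. Compound 3 is therefore estimated at 2600 nM in this assay, within 900 nM to 8000 nM, because compound 1 with two methoxy groups gives 2100 nM.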

Compound 3, half-maximal inhibitory concentration: 2400 nM
Beside the measured number, compound 3's estimate is 1.1-fold (0.03 log units) above it, and the stated range covers the measured number.
By their numbers in this assay, from the lowest: compounds 1, 3 and 2 (each within the scatter of the next).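

On the carbonyl carbon, 2,4-dimethoxyphenyl stands in place of 1H-indol-3-yl with a 1.3-fold lower number from compound 2 to compound 3 (0.12 log units; within the scatter) in this assay. This first matched pair shows that the number in this assay does not separate from the scatter when the fused ring system and its hydrogen-bond donor give way to a single six-membered aromatic ring with two methoxy groups. No measurement on record accounts for this result.

Still open, going by these compounds, is whether a phenyl bearing an amine or a carboxylic acid on the carbonyl carbon would give a step beyond the scatter.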